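A Chloro Group Enters: From Compound 3 to Compound 4

The compounds below may be only part of what the source reports. "The series", "measured", "known", "first", "only" and "open" are said of these compounds alone.

Three compounds sharing one core have been examined in an ADME assay for permeability, using PAMPA, at pH 7.4; a lower number here means that the compound crosses the layer more slowly, a higher number that the compound crosses the layer faster. Compound 2 `O=C(Nc1cccc(-c2nc3ccccc3s2)c1)c1cc([N+](=O)[O-])c(O)cc1Cl` gives 307 10^-6 cm/s. Compound 3 `O=C(Nc1cccc(-c2nc3ccccc3s2)c1)c1cc([N+](=O)[O-])ccc1Cl` gives 12 10^-6 cm/s, the lower of the two numbers. Compound 1 `COc1ccc(-c2nc3ccccc3s2)cc1NC(=O)c1cc([N+](=O)[O-])ccc1Cl` returns no number in this assay, only the entry "below limit of detection" (no number reported). For the measured compounds named here, the single step between measured compounds is a 26-fold lower number from compound 2 to compound 3 (1.41 log units; beyond the scatter), and it places compound 3 at the bottom of the known numbers, with compound 2 as its nearest neighbour and a third entry that carries no number at all.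

Compound 4 `O=C(Nc1ccc(Cl)c(-c2nc3ccccc3s2)c1)c1cc([N+](=O)[O-])ccc1Cl` is compound 3 with one change: chloro in place of hydrogen on an aromatic carbon. Going by the values given here, no measured step involves a chloro group entering or leaving, so nothing among the measured pairs bears directly on this change; the one known step concerns a hydroxy group and cannot simply be carried over. Without such guidance, the expectation in this assay is a step from compound 3 to compound 4 no larger than the usual scatter, in no particular direction, so the expected step is no change at the digits printed from compound 3 to compound 4 (within the scatter). On that basis compound 4 is estimated at 12 10^-6 cm/s in this assay, with a range from 4 10^-6 cm/s to 40 10^-6 cm/s.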

Compound 4, apparent permeability: 3 10^-6 cm/s
For compound 4 the middle estimate is 4.0-fold (0.60 log units) above the measured one, outside the stated range (below it).
By their numbers in this assay, from the lowest: compound 4; then compound 3; then compound 2.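

In this assay, putting a single chloro in place of hydrogen on an aromatic carbon, ortho to the 1,3-benzothiazol-2-yl group and para to a large group, gives a 4.0-fold lower number from compound 3 to compound 4 (0.60 log units; beyond the scatter) and so shows that this position responds to even a one-atom change. For the compounds shown here, until now the only step available concerned a hydroxy group, a 26-fold lower number from compound 2 to compound 3 (1.41 log units; beyond the scatter), so this is the first measured change at this place, and it is labelled modest where the hydroxy step is labelled large, while compound 4 now holds the lowest of the three numbers. Nothing shown here offers a measured explanation for the step, so it stands as an observation only.

On these data alone, with one new group at one position, it remains open whether the lower number belongs to chloro in particular or would follow any group placed on this carbon. An amine or a carboxylic acid on the same carbon, or the same chloro moved to another carbon of this ring, would help separate the effect of the group from that of its place.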